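This account rests on a few compounds, and the source may have more. Where it says the series, first, only, none or still open, it means among the compounds named here.

Of the compounds shown here, three built on a shared core have been measured in a functional assay on T47D cells (Homo sapiens) for activation; a lower number here means that less compound is needed, a higher number that more compound is needed for the effect. Compound 1 `CCNc1ccc2c(c1)OC(N)=C(C#N)C2c1cccc([N+](=O)[O-])c1` gives 110000000 nM in this assay, and compound 2 `CCNc1ccc2c(c1)OC(N)=C(C#N)C2c1cccc(OC)c1` gives 110000000 nM. Among the measured compounds shown here, the single change between these two, a methoxy in place of a nitro on an aromatic carbon, produced no change at the digits printed from compound 1 to compound 2 (within the scatter). Compound 3 `COc1cc(C2C(C#N)=C(N)Oc3c2ccc(N)c3C)cc(Br)c1OC` gives 26000000 nM, the lowest of the three numbers; the values of compound 1 and compound 2 both lie beyond the scatter above it, so compound 3 is the one for which the least compound is needed.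

Compound 4 `COc1cc(C2C(C#N)=C(N)Oc3cc(N)ccc32)cc(Br)c1OC` differs from compound 3 in one place: hydrogen in place of methyl on an aromatic carbon. The methyl that leaves sits on an aromatic carbon of the fused two-ring system of the core, ortho to an amino group. For the measured compounds named here, no measured step covers a change of this kind; the only known step, from compound 1 to compound 2, concerns a different group and was flat. With nothing to point either way, the expected step from compound 3 to compound 4 is a 1.2-fold higher number from compound 3 to compound 4 (0.09 log units; within the scatter), none beyond the scatter. Compound 4 is therefore expected to give about 32000000 nM in this assay, within a range from 9000000 nM to 120000000 nM.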

Compound 4, half-maximal effective concentration: 33000000 nM
Estimate against measurement, compound 4: 1.0-fold (0.01 log units) below; the measured number falls inside the stated range.
By their numbers in this assay, from the lowest: compounds 3 and 4 (each within the scatter of the next); then compounds 1 and 2 (each within the scatter of the next).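

In this assay, hydrogen in place of methyl on this aromatic carbon, ortho to an amino group, gives a 1.3-fold higher number from compound 3 to compound 4 (0.10 log units; within the scatter), so in this one pair the single carbon of the methyl can go without a change that stands out from the scatter. Among the compounds shown here, the only earlier step concerned a nitro and a methoxy at another place on the core, so this is the first reading at this aromatic carbon, and it is flat as well. Nothing measured here explains why this step is so small.

Among the compounds shown, only methyl and hydrogen stand at this carbon, so it remains open whether a chlorine atom, a hydroxyl group or a longer chain such as propyl would leave the number just as unmoved. Going by these compounds, it also remains open whether the step would stay this small on the core of compound 1, which carries an ethylamino group rather than an amino group.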